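This account rests on a few compounds, and the source may have more. Where it says the series, first, only, none or still open, it means among the compounds named here.

Measured so far in a functional assay on HCT-116 cells (Homo sapiens) for antiproliferative activity, read by MTT assay, with a stated time of 48 h; on this read-out higher numbers stand for weaker inhibition and lower numbers for stronger inhibition:
Compound 1 `Cc1ccc(-n2nncc2CN2C(=O)C3(C(C#N)=C(N)Oc4c3c3nc5ccccc5nc3c3ccccc43)c3ccccc32)cc1Cl` gives > 50000 nM, which is a limit of the assay rather than a number.
Compound 2 `Cc1ccc(Cl)cc1-n1nncc1CN1C(=O)C2(C(C#N)=C(N)Oc3c2c2nc4ccccc4nc2c2ccccc32)c2ccccc21` gives > 50000 nM, again a limit of the assay.
Compound 3 `Cc1ccc(-n2nncc2CN2C(=O)C3(C(C#N)=C(N)Oc4c(N)cc5nc6ccccc6nc5c43)c3ccccc32)cc1Cl` gives > 50000 nM, also a limit of the assay.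

All three values sit at the limit of > 50000 nM in this assay, at which 3 of the 3 values shown sit, so none of these compounds has yet shown a measurable number in this assay. Compound 1 and compound 2 differ by one change, (5-chloro-2-methylphenyl in place of 3-chloro-4-methylphenyl on an aromatic nitrogen). The step this change made, a step that the two limits leave unreadable from compound 1 to compound 2, cannot be read in size because both ends sit at the limit of > 50000 nM in this assay, at which 3 of the 3 values shown sit.

Compound 4 `Cc1ccc(Cl)cc1-n1nncc1CN1C(=O)C2(C(C#N)=C(N)Oc3c(N)cc4nc5ccccc5nc4c32)c2ccccc21` has not yet been measured. It arises from compound 3 by 5-chloro-2-methylphenyl in place of 3-chloro-4-methylphenyl on an aromatic nitrogen, the same change as before, since the surroundings of the place are described in the same words. How the core of compound 3 differs from the core of compound 1 is not broken down here.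

For the step from compound 3 to compound 4, I expect, as with the earlier one, no readable size, a step that the limit leaves unreadable from compound 3 to compound 4, an expectation resting on compound 3 sitting at the limit of > 50000 nM in this assay, at which 3 of the 3 values shown sit. Compound 4 is therefore expected to give about 80000 nM, most likely reported again as a limit, within an expected range from 30000 nM to 300000 nM.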

Compound 4, half-maximal inhibitory concentration: 37200 nM
Beside the measured number, compound 4's estimate is 2.2-fold (0.33 log units) above it; measured number inside the range.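

In this assay, putting 5-chloro-2-methylphenyl in place of 3-chloro-4-methylphenyl on the aromatic nitrogen gives an at least 1.3-fold lower number from compound 3 to compound 4 (0.12 log units; that floor lies within the scatter). As far as these compounds go, this shows that the change can go with a measurable number on the core of compound 3, but compound 3 itself is only a limit, so the real size of the step stays unknown and the smallest size it allows does not by itself establish a real gain. Whether the change carries from one core to the other cannot be judged, since the same change on the core of compound 1 cannot be read: the limit of > 50000 nM in this assay, at which 3 of the 4 values shown sit.

The compounds shown leave open what this change does when both partners give real numbers, which would take a pair with both ends inside the measurable range. They also leave open what a methoxy group in place of the chlorine on the phenyl ring would give in this assay.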